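Urea Aryl Swap: Trifluoromethylphenyl to Dichlorophenyl

The source may hold more compounds than are shown below. What is called first, only, known or untested is meant among the compounds shown, and "the series" means these compounds.

In a functional assay on LOX IMVI cells (Homo sapiens) for inhibition, read by sulforhodamine B assay, with a stated time of 48 h, tested at 10 uM (a lower number here means a stronger effect, a higher number a weaker effect of the compound at the concentration tested), compound 1 `COc1cc2cc(Oc3ccc(NC(=O)Nc4ccccc4)cc3)c(C)nc2cc1OC` gives 82.1%.
In this assay compound 2 `COc1cc2cc(Oc3ccc(NC(=O)Nc4cccc(C(F)(F)F)c4)cc3)c(C)nc2cc1OC` gives 9.78%.

Among the compounds with values here, of the two numbers measured, compound 2 stands lowest, and its only neighbour, compound 1, sits far higher: the one measured step is a number 72.3 percentage points lower from compound 1 to compound 2 (beyond the scatter), well beyond the scatter. Compound 3 `COc1cc2cc(Oc3ccc(NC(=O)Nc4ccc(Cl)c(Cl)c4)cc3)c(C)nc2cc1OC` is the next member of the series, and it differs from compound 2 in one place: 3,4-dichlorophenyl in place of 3-(trifluoromethyl)phenyl on an amide-type nitrogen.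

Within the data shown here, only one measured step bears on this change, and it does so indirectly. The step of a number 72.3 percentage points lower from compound 1 to compound 2 (beyond the scatter) shows that placing a group on this phenyl ring, in place of hydrogen, made a very large difference. It says nothing about swapping one substituted phenyl for another, since no two substituted rings have been compared. The change here keeps a substituted ring in place, so the expectation is a step that is small or moderate, most likely toward a somewhat higher number, as the expected step of a number 12.2 percentage points higher from compound 2 to compound 3 (beyond the scatter) is intended to say. Compound 3 is therefore expected to give about 22%, within a range from 5% to 60%.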

Compound 3, a percentage reported as activity, at one concentration (the size of the read-out at that concentration, not a potency): 23.1%
For compound 3 the middle estimate is 1.1 percentage points below the measured one; low and high end bracket the measured number.
By their numbers in this assay, from the lowest: compound 2; then compound 3; then compound 1.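

Replacing phenyl with 3,4-dichlorophenyl on this amide-type nitrogen gives a number 59 percentage points lower from compound 1 to compound 3 (beyond the scatter) in this assay, so the large drop seen earlier is not unique to the 3-(trifluoromethyl)phenyl group: two different substituted rings now lie far below the plain phenyl ring. Swapping one substituted ring for the other is a much smaller move, a number 13.3 percentage points higher from compound 2 to compound 3 (beyond the scatter), yet it still shows that the two rings are not interchangeable here, with 3-(trifluoromethyl)phenyl keeping the lower number. No measurement at hand explains why these two rings differ or why either one lies so far below the plain phenyl ring.

The compounds shown leave open whether a single chlorine, a methoxy group or an amine on this ring would also give a low number, and which of the two chlorines in compound 3 matters. They also leave open how a butyl chain in place of the ring on this nitrogen would compare, and whether the same order of compounds holds at other concentrations or in other cell lines.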